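From Compound 1 to Compound 4: Adding a Nitro Group

A few compounds are considered here, and "the series" means these few. Any claim that something is new, unique, unknown or untested is made for them only; others in the source may bear on it.

Compound 1 `CCOC(=O)c1c(N)sc(/N=C/c2ccccc2)c1C(=O)OCC` heads a small set tested in a functional assay on T47D cells (Homo sapiens) for inhibition, read by MTT assay, with a stated time of 48 h (on this read-out lower numbers stand for stronger inhibition and higher numbers for weaker inhibition), where compound 1 gives 30300 nM. Its two companions carry a substituent where compound 1 has hydrogen: compound 2 `CCOC(=O)c1c(N)sc(/N=C/c2ccc(OC)cc2)c1C(=O)OCC` gives 31900 nM and compound 3 `CCOC(=O)c1c(N)sc(/N=C/c2ccc(C)cc2)c1C(=O)OCC` gives 37200 nM. Compound 1 has the lowest number of the three, but the steps of a 1.1-fold higher number from compound 1 to compound 2 (0.02 log units; within the scatter) and a 1.2-fold higher number from compound 1 to compound 3 (0.09 log units; within the scatter) both fall within the scatter, as does a 1.2-fold higher number from compound 2 to compound 3 (0.07 log units; within the scatter), so the three cannot be ranked.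

Compound 4 `CCOC(=O)c1c(N)sc(/N=C/c2ccc([N+](=O)[O-])cc2)c1C(=O)OCC` differs from compound 1 by nitro in place of hydrogen on an aromatic carbon; cut one bond further out, the change reads phenyl to 4-nitrophenyl. The steps from compound 1 to compound 2 and from compound 1 to compound 3 bear on this change, each placing a group at the same site, and neither moved the number beyond the scatter. Going by the values given here, no measured step covers a nitro group itself, so the expectation rests on those two alone. The expected step is therefore a 1.0-fold lower number from compound 1 to compound 4 (0.00 log units; within the scatter), nothing beyond the scatter. For compound 4 in this assay the estimate is 30000 nM, with a range from 12000 nM to 75000 nM.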

Compound 4, half-maximal inhibitory concentration: 2300 nM
Estimate against measurement, compound 4: 13-fold (1.12 log units) above, and the stated range ends above it.
By their numbers in this assay, from the lowest: compound 4; then compounds 1, 2 and 3 (each within the scatter of the next).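

In this assay this position proves able to move the number a long way, even though the methoxy and methyl groups left it within the scatter of hydrogen: nitro gives a 13-fold lower number from compound 1 to compound 4 (1.12 log units; beyond the scatter) and a 14-fold lower number from compound 2 to compound 4 (1.14 log units; beyond the scatter) and also a 16-fold lower number from compound 3 to compound 4 (1.21 log units; beyond the scatter). Compound 4 therefore stands apart from all three earlier compounds, so the position's earlier flat response held for those substituents and does not extend to nitro. Nothing available explains why nitro behaves differently from the other groups at this position.

On these data alone, whether this drop belongs to nitro alone or would also follow from a nitrile, a trifluoromethyl group or an amine at the same carbon remains open. So does whether nitro would have a similar effect at another carbon of the same ring.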